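Adding a carbon aromatic ring to compound 3

This account rests on a few compounds, and the source may have more. Where it says the series, first, only, none or still open, it means among the compounds named here.

Measured in a functional assay on HeLa cells (Homo sapiens) for inhibition, read by MTT assay, with a stated time of 48 h; a higher number here means a weaker inhibitor, a lower number a stronger inhibitor:
- Compound 1 `CCOC(=O)C1=C(N/C=N/c2cccnc2Cl)Nc2[nH]nc(C)c2C1c1ccc(N(C)C)cc1`: 4630 nM
- Compound 2 `CCOC(=O)C1=C(N/N=C(/C(=O)Br)c2ccc(Br)cc2)Nc2[nH]nc(C)c2C1c1ccc(N(C)C)cc1`: 68500 nM
- Compound 3 `CCOC(=O)C1=C(NN=C(C#N)C#N)Nc2[nH]nc(C)c2C1c1ccc(N(C)C)cc1`: 15200 nM

Compound 3 holds the middle place of these three values. Compound 4 `CCOC(=O)C1=C(N/N=C(/Cl)c2ccc([N+](=O)[O-])cc2)Nc2[nH]nc(C)c2C1c1ccc(N(C)C)cc1` is compound 3 altered once: a group of 12 heavy atoms (7 carbon, 2 nitrogen, 2 oxygen, 1 chlorine; one six-membered aromatic ring of carbon only) in place of a group of 6 heavy atoms (3 carbon, 3 nitrogen; no ring), on an amine nitrogen. Among the compounds with values here, the nearest precedent is compound 2, whose group also carries one six-membered aromatic ring of carbon only, and a 4.5-fold lower number from compound 2 to compound 3 (0.65 log units; beyond the scatter). Read backwards, that step points to a modest rise in this assay, meaning a weaker inhibitor. Compound 1 goes against any simple rule about ring-bearing groups, since a 3.3-fold higher number from compound 1 to compound 3 (0.52 log units; beyond the scatter). The expected step is therefore modest: a 2.1-fold higher number from compound 3 to compound 4 (0.32 log units; beyond the scatter). Compound 4 is estimated at 32000 nM. The expected range runs from 10000 nM to 90000 nM.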

Compound 4, half-maximal inhibitory concentration: 46200 nM
Beside the measured number, compound 4's estimate is 1.4-fold (0.16 log units) below it; the measured number falls inside the stated range.
By their numbers in this assay, from the lowest: compound 1; then compound 3; then compounds 4 and 2 (each within the scatter of the next).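

In this assay, the result gives a second group with a six-membered aromatic ring of carbon only at this amine nitrogen, and it is a weaker inhibitor than the ring-free group of compound 3 (a 3.0-fold higher number from compound 3 to compound 4 (0.48 log units; beyond the scatter)). The two carbon-ring groups cannot be told apart, despite their different atoms (a 1.5-fold lower number from compound 2 to compound 4 (0.17 log units; within the scatter)). Compound 1 goes against any rule about rings in general: its ring has a hetero atom, and it stands well apart (a 10-fold higher number from compound 1 to compound 4 (1.00 log units; beyond the scatter)).

No measurement shown explains these differences. Going by these compounds, how a longer alkyl chain or a carboxylic acid on this amine nitrogen would read remains open.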